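Swapping the Benzyl Group for a Thiourea on the Ring Amine

The compounds below may be only part of what the source reports. "The series", "measured", "known", "first", "only" and "open" are said of these compounds alone.

Compound 1 `NC(=O)c1c(NC(=O)c2ccccc2Cl)sc2c1CCN(Cc1ccc(Cl)cc1)C2` was tested in a functional assay on MKN-74 cells (Homo sapiens) for antiproliferative activity, with a stated time of 24 h (on this read-out higher numbers stand for weaker inhibition and lower numbers for stronger inhibition), where compound 1 gives 18700 nM. Among the measured compounds shown here, of the two numbers measured so far, this is the higher one. For the measured compounds named here, its only companion is compound 2 `NC(=O)c1c(NC(=O)c2ccc(C(F)(F)F)cc2)sc2c1CCN(Cc1ccc(Cl)cc1Cl)C2`, which in this assay gives 10900 nM; the two values lie within the usual scatter of each other, so neither can be called the stronger inhibitor. Compound 3 `COc1ccc(NC(=S)N2CCc3c(sc(NC(=O)c4ccccc4Cl)c3C(N)=O)C2)cc1` has not been tested yet. Relative to compound 1, the change is a group of 11 heavy atoms (8 carbon, 1 nitrogen, 1 oxygen, 1 sulfur; one six-membered aromatic ring of carbon only) in place of a group of 8 heavy atoms (7 carbon, 1 chlorine; one six-membered aromatic ring of carbon only), on an amine nitrogen in a ring. Going by the values given here, no measured pair shows the effect of this exchange, so nothing in the numbers points in either direction. The step from compound 1 to compound 3 is therefore expected to be about a 1.2-fold lower number from compound 1 to compound 3 (0.10 log units; within the scatter), with no direction beyond the scatter. Compound 3 is expected to give 15000 nM in this assay, with a likely range from 4000 nM to 60000 nM.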

Compound 3, half-maximal inhibitory concentration: 19600 nM
Compound 3: the middle estimate sits 1.3-fold (0.12 log units) below what was measured; measured number inside the range.
By their numbers in this assay, from the lowest: compounds 2, 1 and 3 (each within the scatter of the next).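

Swapping the 4-chlorobenzyl on the amine nitrogen in the ring for the thiourea group is the first single-place change that can be read in this set. In this assay it gives a 1.0-fold higher number from compound 1 to compound 3 (0.02 log units; within the scatter) and so no shift beyond the scatter, even though the entering group is larger and carries hydrogen-bond donors and acceptors that the 4-chlorobenzyl lacks. This is one pair only, and no measured information explains why the two groups read alike.

The compounds shown leave open whether an acetyl group, a sulfonyl group or a longer alkyl chain on this ring nitrogen would give a number beyond the scatter from compound 1. They also leave open whether the thiourea group would read the same on the rest of compound 2.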